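Chain exchange from compound 2 to compound 3

The compounds below may be only part of what the source reports. "The series", "measured", "known", "first", "only" and "open" are said of these compounds alone.

Measured in an ADME assay on microsomes from liver (Mus musculus) for metabolic stability, using NADPH, with a stated time of 10 min; on this read-out lower numbers stand for a less stable compound and higher numbers for a more stable compound:
- compound 1 `CN(C[C@H]1Cc2ncccc2CN1)[C@H]1CCCc2cccnc21` gives 53%
- compound 2 `NC(=O)NC/C=C/CN(C[C@H]1Cc2ncccc2CN1)[C@H]1CCCc2cccnc21` gives 19%

Of the two measured compounds, compound 2 stands lowest at 19%. Compound 1 gives 53% on the same read-out. The gap between the two compounds lies well beyond the scatter.

The next compound is compound 3 `CCN(CC)CCCCN(C[C@H]1Cc2ncccc2CN1)[C@H]1CCCc2cccnc21`, which keeps the shared core and exchanges one open chain for another: a group of 8 heavy atoms (7 carbon, 1 nitrogen; no ring) in place of a group of 7 heavy atoms (4 carbon, 2 nitrogen, 1 oxygen; no ring), on a saturated chain carbon bound to an amine nitrogen. The entering group is 3-(diethylamino)propyl, and it sits on a saturated chain carbon bound to an amine nitrogen.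

Among the compounds with values here, only one measured step bears on this change. It is large and beyond the scatter: a number 34 percentage points lower from compound 1 to compound 2 (beyond the scatter). That step replaces a hydrogen atom with a chain, whereas compound 3 still carries a chain at this place. Within the data shown here, no measured pair shows one chain exchanged for another, so the evidence is thin and the range must stay wide.

Since compound 2 at 19% already carries a chain of similar size, no step beyond the scatter is expected in this assay and no direction can be favoured. The expected step is small: a number 3 percentage points higher from compound 2 to compound 3 (within the scatter).

The estimate for compound 3 is 22%, with an expected range from 6% to 45%.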

Compound 3, percent of the compound remaining: 1%
Estimate against measurement, compound 3: 21 percentage points above; measured number below the stated range.
By their numbers in this assay, from the lowest: compound 3; then compound 2; then compound 1.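

Working notes on the chain at this place. In this assay, the identity of the chain matters as well as its presence: with 3-(diethylamino)propyl taking the place of the chain with 2 hydrogen-bond donors, the read-out gives a number 18 percentage points lower from compound 2 to compound 3 (beyond the scatter), so a similar heavy-atom count does not make two chains equivalent here. Set directly against the hydrogen of compound 1, the same group gives a number 52 percentage points lower from compound 1 to compound 3 (beyond the scatter), and with a number 34 percentage points lower from compound 1 to compound 2 (beyond the scatter) both chains shown at this place stand lower than hydrogen, with no compound among the three going against that; compound 3, at 1%, is the lowest of the series shown. Nothing available bears on what lies behind the difference between the two chains, so the result remains an observation on these compounds alone.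

Still open, going by these compounds, is whether the drop follows from the terminal diethylamine, from the saturated chain or from both, which a chain of the same length ending in a morpholine or a plain butyl chain would help to separate. Also open, on these data alone, is where a short group such as ethyl, or a chain ending in a carboxylic acid, would fall relative to compound 1 in this assay.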